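The source may hold more compounds than are shown below. What is called first, only, known or untested is meant among the compounds shown, and "the series" means these compounds.

Measured so far in a functional assay on MCF7 cells (Homo sapiens) for inhibition, read by MTT assay; on this read-out lower numbers stand for stronger inhibition and higher numbers for weaker inhibition:
compound 1 `CC(C)(C)OC(=O)N1CCN(CC(=O)Nc2ccc(C(=O)/C=C/c3cn(Cc4ccc(Br)cc4)nn3)cc2)CC1`: 31000 nM
compound 2 `CCCCCCCCn1cc(/C=C/C(=O)c2ccc(NC(=O)CN3CCN(c4ccc([N+](=O)[O-])cc4)CC3)cc2)nn1`: 49100 nM
compound 3 `O=C(CN1CCN(c2ccc([N+](=O)[O-])cc2)CC1)Nc1ccc(C(=O)/C=C/c2cn(Cc3ccc(Br)cc3)nn2)cc1`: 31600 nM

Compound 3 stands second highest of these three numbers, but all three sit close together: the step of a 1.0-fold higher number from compound 1 to compound 3 (0.01 log units; within the scatter) and the step of a 1.6-fold lower number from compound 2 to compound 3 (0.19 log units; within the scatter) are both within the scatter, so no ordering can be read from them. Compound 4 `CCCCCCCCCCn1cc(/C=C/C(=O)c2ccc(NC(=O)CN3CCN(c4ccc([N+](=O)[O-])cc4)CC3)cc2)nn1` differs from compound 3 in one place: nonyl in place of 4-bromophenyl on a saturated chain carbon bound to an aromatic nitrogen. Going by the values given here, the only measured step that bears on this change is the one from compound 2 to compound 3, the same kind of exchange taken the other way with a shorter chain, and it stayed within the scatter. Nothing here points to a shift in either direction in this assay. Compound 4 is therefore expected to land at about 40000 nM, with a range of 18000 nM to 90000 nM, which means an expected step of a 1.3-fold higher number from compound 3 to compound 4 (0.10 log units; within the scatter).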

Compound 4, half-maximal inhibitory concentration: 44400 nM
Compound 4: the middle estimate sits 1.1-fold (0.05 log units) below what was measured, within the range that was stated.
By their numbers in this assay, from the lowest: compounds 1, 3, 4 and 2 (each within the scatter of the next).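

In this assay, a 4-bromobenzyl ring and a decyl chain on the aromatic nitrogen are not told apart (a 1.4-fold higher number from compound 3 to compound 4 (0.15 log units; within the scatter)). This holds for a ring against a plain chain, which compound 3 and compound 4 now show at the longer chain length. Ethyl in place of hydrogen at the chain end is also not told apart (a 1.1-fold lower number from compound 2 to compound 4 (0.04 log units; within the scatter)), so these chain lengths cannot be separated either. No measurement here offers a reason. Still open, going by these compounds, is whether an amine or a carboxylic acid at this position would move the number beyond the scatter.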